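The source may hold more compounds than are shown below. What is called first, only, known or untested is meant among the compounds shown, and "the series" means these compounds.

Three compounds have a value in an assay on T-REx-293 cells for inhibition of potassium channel subfamily T member 1 (Homo sapiens), read by patch clamp; a lower number here means a stronger inhibitor, a higher number a weaker inhibitor:

compound 1 `Cc1cccc(-c2noc([C@H](C)NC(=O)c3cc(C4CC4)n(C)n3)n2)c1`: > 30000 nM
compound 2 `CCc1cc(C(=O)N[C@@H](C)c2nc(-c3cccc(C)c3)no2)n(C)n1`: 335 nM
compound 3 `C[C@H](NC(=O)c1cc(C(F)(F)F)nn1C)c1nc(-c2ccccn2)no1`: > 30000 nM

Compound 3 gives no number in this assay, only a limit. Compound 3 stands at the limit of > 30000 nM in this assay, at which 2 of the 3 values shown sit. Among the compounds with values here, compound 2 is the only one of the three with a measured number in this assay, and no pair among the measured compounds differs in one place alone, so no step can be read from them.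

Compound 4 `C[C@H](NC(=O)c1cc(C(F)(F)F)nn1C)c1nc(-c2ccnc(N(C)C)c2)no1` is not yet measured. It differs from compound 3 by 2-(dimethylamino)pyridin-4-yl in place of pyridin-2-yl on an aromatic carbon. Whether this change moves the value in this assay can only be guessed, since compound 3 offers a limit and not a number. Compound 4 is expected to show an at least 3.7-fold lower number from compound 3 to compound 4 (0.57 log units; beyond the scatter), most likely downward from the limit, but possibly no measurable change at all. The estimate for compound 4 in this assay is 8000 nM, between 1500 nM and 30000 nM.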

Compound 4, half-maximal inhibitory concentration: 454 nM
Beside the measured number, compound 4's estimate is 18-fold (1.25 log units) above it, outside the stated range (below it).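

In this assay, the aromatic carbon between two ring nitrogen atoms proves to be a place where a single change carries the value clear of the limit: 2-(dimethylamino)pyridin-4-yl in place of pyridin-2-yl gives an at least 66-fold lower number from compound 3 to compound 4 (1.82 log units; beyond the scatter) with the rest of the structure unchanged. This is the first step that can be read among the compounds shown, and its size is a floor rather than an exact figure. Compound 3 holds only a limit, not a number: the limit of > 30000 nM in this assay, at which 2 of the 4 values shown sit.

The change swaps pyridin-2-yl for a pyridin-4-yl and adds the dimethylamino group in one move, so the compounds shown do not separate the two. From the compounds shown here alone, whether plain pyridin-4-yl, or a morpholine or a methoxy group in place of the dimethylamino group, would give a similar value remains open.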